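The source may hold more compounds than are shown below. What is called first, only, known or untested is meant among the compounds shown, and "the series" means these compounds.

Compound 2 `O=C(NCC1CCCCC1)c1cccc(/C=C2\CC(=O)N(c3ccccc3)C2=O)c1` carries a cyclohexylmethyl group on its amide-type nitrogen. In an ADME assay on SW480 cells (Homo sapiens) for cytotoxicity, read by MTT assay, with a stated time of 72 h (a lower number here means a stronger inhibitor, a higher number a weaker inhibitor), compound 2 reaches only the limit of the assay, > 100000 nM, so no number is known for it. Its one measured relative, compound 1 `Cc1cccc(NC(=O)c2cccc(/C=C3\CC(=O)N(c4ccccc4)C3=O)c2)c1`, carries 3-methylphenyl in the same place. In this assay compound 1 also gives only a limit, > 100000 nM. The step that the two limits leave unreadable from compound 1 to compound 2 therefore cannot be read, since both ends are limits. Compound 3 `O=C(Nc1ccc(F)cc1)c1cccc(/C=C2\CC(=O)N(c3ccccc3)C2=O)c1` has not been measured; it differs from compound 2 by 4-fluorophenyl in place of cyclohexylmethyl on an amide-type nitrogen. Among the measured compounds shown here, the only measured step that touches this position is the one between compound 1 and compound 2, and its size is not readable; the whole picture so far is summed up by the limit of > 100000 nM in this assay, at which 2 of the 2 values shown sit. For the measured compounds named here, no measured step gives a direction, so nothing beyond the scatter can be argued for the change from compound 2 to compound 3, and a further limit is the likeliest outcome. Compound 3 is therefore expected to give about 150000 nM, with a range from 60000 nM to 500000 nM. The step that the limit leaves unreadable from compound 2 to compound 3 is accordingly expected to be essentially nil.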

Compound 3, half-maximal inhibitory concentration: > 100000 nM
Compound 3 ended at the assay's limit (the forecaster's own chance of this, stated with the estimate: 80%); the middle value lies beyond the limit too.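

In this assay compound 3 gives > 100000 nM, which is a limit of the assay. No step among compound 1, compound 2 and compound 3 can be read, since all of them end at the same limit: the limit of > 100000 nM in this assay, at which 3 of the 3 values shown sit.

The compounds shown leave open whether any group on the amide-type nitrogen, or any change elsewhere on the shared core, would give a measurable value in this assay.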